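Chain and ring change from compound 2 to compound 4

The source may hold more compounds than are shown below. What is called first, only, known or untested is meant among the compounds shown, and "the series" means these compounds.

Three compounds measured so far in a functional assay on BCG823 cells (Homo sapiens) for antiproliferative activity, read by MTT assay, with a stated time of 48 h; a higher number here means a weaker inhibitor, a lower number a stronger inhibitor
compound 1 `COc1c(OCCCN2CCCC2)cc2oc(-c3ccccc3)cc(=O)c2c1O` gives 12000 nM
compound 2 `COc1c(OCCCN2CCCCC2)cc2oc(-c3ccccc3)cc(=O)c2c1O` gives 9700 nM
compound 3 `COc1c(OCCCCN2CCCC2)cc2oc(-c3ccccc3)cc(=O)c2c1O` gives 9500 nM

Compound 2 stands level with the other two measured compounds. The steps of a 1.2-fold lower number from compound 1 to compound 2 (0.09 log units; within the scatter) and a 1.0-fold lower number from compound 2 to compound 3 (0.01 log units; within the scatter) both stay within the scatter. The change (4-methylpiperazin-1-yl)methyl in place of piperidin-1-yl on a saturated chain carbon, three bonds along the chain from an oxygen on an aromatic ring puts (4-methylpiperazin-1-yl)methyl in place of piperidin-1-yl on a saturated chain carbon and gives compound 4 `COc1c(OCCCCN2CCN(C)CC2)cc2oc(-c3ccccc3)cc(=O)c2c1O` as the result. The closest measured change is (pyrrolidin-1-yl)methyl in place of piperidin-1-yl, already seen above, and the step of a 1.3-fold lower number from compound 1 to compound 3 (0.10 log units; within the scatter) is equally within the scatter. Going by the values given here, no measured compound carries (4-methylpiperazin-1-yl)methyl, so that ring remains untested. No step beyond the scatter is expected, and the estimated 1.1-fold lower number from compound 2 to compound 4 (0.03 log units; within the scatter) stays small in this assay as well. For compound 4 the estimate is 9000 nM with an expected range from 4000 nM to 20000 nM overall.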

Compound 4, half-maximal inhibitory concentration: 35800 nM
Estimate against measurement, compound 4: 4.0-fold (0.60 log units) below; the measured number lies above the stated range.
By their numbers in this assay, from the lowest: compounds 3, 2 and 1 (each within the scatter of the next); then compound 4.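

In this assay, going by these compounds alone, this is the first change on the side chain to go beyond the scatter, with a 3.7-fold higher number from compound 2 to compound 4 (0.57 log units; beyond the scatter) and a 3.8-fold higher number from compound 3 to compound 4 (0.58 log units; beyond the scatter) and a 3.0-fold higher number from compound 1 to compound 4 (0.47 log units; beyond the scatter) as the readings. The position therefore does not tolerate every ring equally: compound 4, bearing 4-methylpiperazin-1-yl, is a weaker inhibitor than the piperidin-1-yl and pyrrolidin-1-yl compounds. Nothing available accounts for this loss.

From the compounds shown here alone, it remains open whether the loss follows the second ring nitrogen or its methyl group. A morpholin-4-yl ring or an unsubstituted piperazin-1-yl ring on the same chain would separate the two, and neither is among the compounds shown.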